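Adding a methyl to the ring nitrogen of compound 3

The source may report more compounds than this note shows. Statements on the series, on what has been measured and on what is new or still open speak of the compounds shown alone.

In an in vitro functional assay on SH-EP1 cells for agonist activity at Neuronal acetylcholine receptor; alpha4/beta2 (Homo sapiens), read by voltage clamp (a higher number here means a larger maximal response, a lower number a smaller maximal response), three compounds have been measured so far:

Compound 1, `CN1C[C@H]2C=C(c3cccnc3)C[C@H](C2)C1`, gives 19%.
Compound 2, `C1=C(c2cccnc2)C[C@H]2CNC[C@@H]1C2`, gives 40%.
Compound 3, `C1=C(c2cccnc2)C[C@@H]2CNC[C@H]1C2`, gives 32%.

Compound 3 stands second of the three. Its nearest neighbour is compound 2, which sits within the usual scatter of it, so the two cannot be told apart; compound 1 lies furthest below, a gap large enough to count as real.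

Compound 4, `CN1C[C@@H]2C=C(c3cccnc3)C[C@@H](C2)C1`, has not yet been measured. It differs from compound 3 in one place: methyl in place of hydrogen on an amine nitrogen in a ring.

Among the compounds with values here, two measured steps bear on this. First, a number 21 percentage points higher from compound 1 to compound 2 (beyond the scatter), which is the same exchange run the other way round on the mirror-image pair. Second, a number 8 percentage points lower from compound 2 to compound 3 (within the scatter), which shows that swapping the two mirror images changes little; this rests on (the fact that compounds 2 and 3 differ only in the configuration as drawn). Compound 4 is the mirror image of compound 1, just as compound 3 is of compound 2, so the methyl is expected to cost roughly what its removal gained.

For compound 4 a drop is therefore expected, a number 19 percentage points lower from compound 3 to compound 4 (beyond the scatter). Compound 4 is estimated to give 13%, with a likely range from 4% to 25%.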

Compound 4, largest response reached (reported as percent of maximum), in percent of the reference or control that the assay uses: 18%
Estimate against measurement, compound 4: 5 percentage points below; the measured number falls inside the stated range.
By their numbers in this assay, from the lowest: compounds 4 and 1 (each within the scatter of the next); then compounds 3 and 2 (each within the scatter of the next).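

In this assay, methyl on the amine nitrogen in a ring now goes with a lower number on both mirror-image forms, as a number 14 percentage points lower from compound 3 to compound 4 (beyond the scatter) matches the earlier step on the other form: the same change on two cores in this assay, a number 21 percentage points higher (beyond the scatter) from compound 1 to compound 2 and a number 14 percentage points higher (beyond the scatter) from compound 4 to compound 3, 7 percentage points apart, within the scatter of two such steps. The new compound also tests the mirror-image swap on the methylated pair, and as on the pair without methyl, the swap makes no readable difference, with a number 1 percentage points lower from compound 1 to compound 4 (within the scatter): the fact that compounds 1 and 4 differ only in the configuration as drawn. Across these four compounds, then, the choice of hydrogen or methyl on this nitrogen separates the numbers, while the drawn configuration does not, and no compound shown goes against this.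

The compounds shown carry only hydrogen or methyl at this nitrogen, so it remains open whether an ethyl group or a longer chain would take the response lower still or leave it where methyl does. On these data alone, the largest response also tells nothing about the concentration needed to reach it, so how these four compounds compare on that measure is unknown.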